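The source may hold more compounds than are shown below. What is called first, only, known or untested is meant among the compounds shown, and "the series" means these compounds.

In an ADME assay on MT4 cells (Homo sapiens) for cytotoxicity, read by MTT assay, with a stated time of 96 h (a lower number here means that less compound is tolerated, a higher number that more compound is tolerated), compound 1, with the structure `C/C(=N\NC(N)=S)c1ccc2[nH]c(-c3ccc(C(F)(F)F)cc3)nc2c1`, gives 2000 nM. Compound 2, with the structure `COc1ccc(-c2nc3cc(/C(C)=N/NC(N)=S)ccc3[nH]2)cc1`, gives 5000 nM in this assay. The two are measured and differ in one place: methoxy in place of trifluoromethyl on an aromatic carbon. This change produced a 2.5-fold higher number from compound 1 to compound 2 (0.40 log units; beyond the scatter).

Compound 3, with the structure `CC(=O)c1ccc2c(c1)nc(-c1ccc(C(F)(F)F)cc1)n2C1CCCCC1`, gives 41000 nM in this assay, the highest of the three numbers, beyond the scatter from both others. How compound 3 differs from compound 1 is not broken down here; the two cores differ in more than one place.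

Compound 4, with the structure `COc1ccc(-c2nc3cc(C(C)=O)ccc3n2C2CCCCC2)cc1`, has not yet been measured. It stands to compound 3 as compound 2 stands to compound 1, the same change at the same place: methoxy in place of trifluoromethyl on an aromatic carbon. That change occurs twice among these compounds, once measured and once not.

For compound 4 the writer expects a step of about a 2.2-fold higher number from compound 3 to compound 4 (0.34 log units; beyond the scatter) in this assay, resting only on the size of a 2.5-fold higher number from compound 1 to compound 2 (0.40 log units; beyond the scatter) and on the starting number of compound 3 at 41000 nM. Within the data shown here, because a 2.5-fold higher number from compound 1 to compound 2 (0.40 log units; beyond the scatter) is modest and is the only measured example of this change, the expectation is held loosely. The estimate for compound 4 in this assay is 90000 nM, with a range from 40000 nM to 200000 nM.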

Compound 4, half-maximal cytotoxic concentration: 27000 nM
Beside the measured number, compound 4's estimate is 3.3-fold (0.52 log units) above it; measured number below the stated range.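

On the core of compound 3, the replacement of trifluoromethyl by methoxy gives, in this assay, a 1.5-fold lower number from compound 3 to compound 4 (0.18 log units; within the scatter), so this pair is not separated by the change. Set beside the earlier pair, the same replacement does not carry over from one core to the other with the same size: the same change on two cores in this assay, a 2.5-fold higher number (0.40 log units; beyond the scatter) from compound 1 to compound 2 and a 1.5-fold lower number (0.18 log units; within the scatter) from compound 3 to compound 4, 3.8-fold (0.58 log units) apart, beyond the scatter of two such steps. Among these compounds, this shows that, in this series, the step seen on the core of compound 1 cannot simply be transferred to the core of compound 3, but it does not show which of the several differences between these two cores lies behind the gap, and with only one pair on each core it gives no rule for how the replacement behaves in general.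

The compounds shown leave open whether the same gap between the two cores would appear with other groups on that aromatic carbon, such as an amine, a carboxylic acid or a longer alkoxy chain in place of the methoxy. They also leave open how the replacement of trifluoromethyl by methoxy would read on a third core, and so whether either of the two steps is the more typical one.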